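This account rests on a few compounds, and the source may have more. Where it says the series, first, only, none or still open, it means among the compounds named here.

Measured compounds in an ADME assay (Rattus norvegicus) for inhibition; on this read-out higher numbers stand for weaker inhibition and lower numbers for stronger inhibition:
compound 1 `Cc1nc2c([nH]1)C(=O)/C(=N/c1cccc(Cl)c1Cl)C(Cl)=C2O` gives 600 nM
compound 2 `O=C1C=C(Nc2ccc(Cl)cc2)C(=O)c2[nH]c(-c3ccccn3)nc21` gives 13000 nM
compound 3 `O=C1C=C(Nc2ccc(I)cc2)C(=O)c2[nH]c(-c3ccccn3)nc21` gives 20000 nM

Compound 3 carries the highest of the three numbers in this assay. Its nearest neighbour is compound 2, and the step of a 1.5-fold higher number from compound 2 to compound 3 (0.19 log units; within the scatter) is within the scatter, so these two cannot be ordered against each other. Among the measured compounds shown here, compound 1 stands far lower; it differs from the shared core of compounds 2 and 3 in more than one place, so no single step is stated for it.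

Compound 4 `O=C1C=C(Nc2ccc(OC(F)(F)F)cc2)C(=O)c2[nH]c(-c3ccccn3)nc21` is not yet measured. It differs from compound 3 by trifluoromethoxy in place of iodo on an aromatic carbon. For the measured compounds named here, the only measured step that bears on this change is the exchange of the group on an aromatic carbon between compound 2 and compound 3, a 1.5-fold higher number from compound 2 to compound 3 (0.19 log units; within the scatter), which stayed within the scatter. Going by the values given here, no measured step involves a trifluoromethoxy group, so the data give no further guide. On that basis the expected step in this assay is a 1.3-fold lower number from compound 3 to compound 4 (0.12 log units; within the scatter), not beyond the scatter. For compound 4 the estimate in this assay is 15000 nM, with a range from 5000 nM to 45000 nM.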

Compound 4, half-maximal inhibitory concentration: 20000 nM
For compound 4 the middle estimate is 1.3-fold (0.12 log units) below the measured one; the measured number falls inside the stated range.
By their numbers in this assay, from the lowest: compound 1; then compounds 2, 3 and 4 (each within the scatter of the next).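

In this assay, trifluoromethoxy in place of iodo gives no change at the digits printed from compound 3 to compound 4 (within the scatter), and trifluoromethoxy in place of chloro gives a 1.5-fold higher number from compound 2 to compound 4 (0.19 log units; within the scatter). The position on the aromatic carbon, para to a large group, has now carried chloro, iodo and trifluoromethoxy in compounds 2, 3 and 4 with no step beyond the scatter, even though trifluoromethoxy brings 5 heavy atoms and 1 hydrogen-bond acceptor where iodo brings 1 heavy atom and none. No supporting measurement is available to account for this lack of a readable difference.

As far as these compounds go, whether an amine or a carboxylic acid at this position would give a step beyond the scatter remains open. Compound 1 differs from compounds 2, 3 and 4 in more than one place, so the data do not show which of its differences goes with its lower number.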